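Replacing a fluoro-methylphenyl tail with phenoxy: permeability

A few compounds are considered here, and "the series" means these few. Any claim that something is new, unique, unknown or untested is made for them only; others in the source may bear on it.

Measured so far:
Compound 1 `Cc1c(F)cccc1CCCCOc1ccc(/C=C/c2cccc3c(CCCC(=O)O)c(C)n(CC(=O)O)c23)cc1`: 4 10^-6 cm/s
Compound 2 `Cc1c(F)cccc1CCCCOc1ccc(/C=C/c2cccc3c(CCCC(=O)O)cn(CC(=O)O)c23)cc1`: 3.5 10^-6 cm/s

In a physicochemical assay for permeability, using PAMPA, with a stated time of 4 h, at pH 6.2, tested at 50 uM (a higher number here means that the compound crosses the layer faster, a lower number that the compound crosses the layer more slowly), compound 2 gives the lowest of the two numbers, and its nearest neighbour is compound 1 with 4 10^-6 cm/s. Going by the values given here, the only measured step, a 1.1-fold lower number from compound 1 to compound 2 (0.06 log units; within the scatter), lies within the scatter. Compound 3 `O=C(O)CCCc1cn(CC(=O)O)c2c(/C=C/c3ccc(OCCCCOc4ccccc4)cc3)cccc12` carries the change (phenoxy in place of 3-fluoro-2-methylphenyl on a saturated chain carbon, four bonds along the chain from an oxygen on an aromatic ring). Among the compounds with values here, no measured step touches this part of the molecule, so the expectation rests only on the near-constant numbers seen so far. The step of no change at the digits printed from compound 2 to compound 3 (within the scatter) is therefore expected to stay within the scatter. Compound 3 is estimated at 3.5 10^-6 cm/s, in the range 1.5 10^-6 cm/s to 8 10^-6 cm/s.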

Compound 3, apparent permeability: 1.6 10^-6 cm/s
Compound 3: middle estimate off by 2.2-fold (0.34 log units), on the high side; low and high end bracket the measured number.
By their numbers in this assay, from the lowest: compound 3; then compounds 2 and 1 (each within the scatter of the next).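

In this assay, going by these compounds alone, swapping 3-fluoro-2-methylphenyl for phenoxy on the chain gives a 2.2-fold lower number from compound 2 to compound 3 (0.34 log units; beyond the scatter), the first step in this set to go beyond the scatter. So this end of the molecule can move the number, whereas the one earlier step, made elsewhere, did not. The swap changes several things at once: an oxygen enters, while a fluorine and a methyl leave. Nothing available here explains the drop. On these data alone, it remains open which of these matters, and whether a plain phenyl or an amine in place of the phenoxy oxygen would give a similar number.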